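The compounds below may be only part of what the source reports. "The series", "measured", "known", "first", "only" and "open" are said of these compounds alone.

Series notes on the sulfonamide nitrogen substituent. In an assay for inhibition of serine/threonine-protein kinase PLK2 (Homo sapiens), read by FRET and Z'-LYTE, with a stated time of 1 h (a higher number here means a weaker inhibitor, a lower number a stronger inhibitor), compound 1 `CCCNS(=O)(=O)c1ccc(Nc2ncc3c(n2)N(C2CCCC2)[C@H](CC)C(=O)N3C)cc1` gives 17.8 nM. Compound 2 `CC[C@@H]1C(=O)N(C)c2cnc(Nc3ccc(S(=O)(=O)NC4CCCC4)cc3)nc2N1C1CCCC1` gives 23.9 nM in this assay; the change there is cyclopentyl in place of propyl on a sulfonamide nitrogen, and the step is a 1.3-fold higher number from compound 1 to compound 2 (0.13 log units; within the scatter). Compound 3 `CC[C@@H]1C(=O)N(C)c2cnc(Nc3ccc(S(=O)(=O)NC)cc3)nc2N1C1CCCC1` gives 3.4 nM in this assay and holds the lowest of the three numbers, separated from both others by steps beyond the scatter: a 5.2-fold lower number from compound 1 to compound 3 (0.72 log units; beyond the scatter) and a 7.0-fold lower number from compound 2 to compound 3 (0.85 log units; beyond the scatter).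

Compound 4 `CC[C@@H]1C(=O)N(C)c2cnc(Nc3ccc(S(=O)(=O)Nc4ccccc4)cc3)nc2N1C1CCCC1` is not yet measured. It differs from compound 3 as follows: phenyl in place of methyl on a sulfonamide nitrogen. For the measured compounds named here, two measured steps bear on this change, since both run toward a smaller group on the same nitrogen and both lowered the number by a modest amount, namely a 5.2-fold lower number from compound 1 to compound 3 (0.72 log units; beyond the scatter) and a 7.0-fold lower number from compound 2 to compound 3 (0.85 log units; beyond the scatter). Going the other way, from methyl to a larger group, a modestly higher number in this assay is expected for compound 4, although phenyl is aromatic and no aromatic group on this nitrogen has been tried, so the size is uncertain. Compound 4 is expected at 15 nM, within a range from 5 nM to 45 nM. For compound 4 this amounts to an expected step of a 4.4-fold higher number from compound 3 to compound 4 (0.64 log units; beyond the scatter).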

Compound 4, half-maximal inhibitory concentration: 54.4 nM
For compound 4 the middle estimate is 3.6-fold (0.56 log units) below the measured one, outside the stated range (above it).
By their numbers in this assay, from the lowest: compound 3; then compounds 1 and 2 (each within the scatter of the next); then compound 4.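

Within this set, phenyl on the sulfonamide nitrogen costs more than any saturated group tried: in this assay the change from methyl is large (a 16-fold higher number from compound 3 to compound 4 (1.20 log units; beyond the scatter)), and compound 4 has the highest number of the four, beyond the scatter from every other compound. The aromatic ring also stands apart from the two larger saturated groups, with modest steps from cyclopentyl (a 2.3-fold higher number from compound 2 to compound 4 (0.36 log units; beyond the scatter)) and from propyl (a 3.1-fold higher number from compound 1 to compound 4 (0.49 log units; beyond the scatter)), although compound 1 and compound 2 lie within the scatter of each other, so the larger groups do not share one level at this position. Nothing at hand accounts for the separation of phenyl from the saturated groups or for the large step from methyl.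

Open at the small end is whether the bare sulfonamide, with hydrogen in place of methyl, or an ethyl group would give a number near that of compound 3. Open among the ring groups is whether a benzyl group, a pyridine ring or a phenyl ring bearing a fluorine or a methoxy group would stay near compound 4 or move toward the saturated groups.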